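A few compounds are considered here, and "the series" means these few. Any claim that something is new, unique, unknown or untested is made for them only; others in the source may bear on it.

Measured compounds:
- compound 1 `Cc1ccc(-c2noc(-c3ccc(C(=O)C(F)(F)F)s3)n2)cc1` gives 110 nM in an assay for inhibition of histone deacetylase 4 (Homo sapiens); on this read-out higher numbers stand for weaker inhibition and lower numbers for stronger inhibition
- compound 2 `O=C(c1ccc(-c2nc(-c3ccc(C(F)(F)F)cc3)no2)s1)C(F)(F)F` gives 200 nM in this assay

Among the measured compounds shown here, compound 1 holds the lower of these two numbers in this assay, and its only neighbour is compound 2, reached by a 1.8-fold higher number from compound 1 to compound 2 (0.26 log units; within the scatter), a step that lies within the scatter of repeated measurements. The two compounds are thus not separated by the data.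

Compound 3 `O=C(c1ccc(-c2nc(-c3cccnc3)no2)s1)C(F)(F)F` has not yet been measured in this assay. It arises from compound 1 by pyridin-3-yl in place of 4-methylphenyl on an aromatic carbon. For the measured compounds named here, the one measured step, a 1.8-fold higher number from compound 1 to compound 2 (0.26 log units; within the scatter), concerns a change on the same ring that is now exchanged, but it only swaps one small group on that ring for another and leaves the ring itself untouched; in compound 3 the whole ring is replaced by a different one. That step gives a weak guide at best: it shows that a change at this part of compound 1 produced no movement beyond the scatter, but it says nothing direct about swapping the ring for one carrying a ring nitrogen. Compound 3 is therefore expected to land near compound 1, with the estimated step of a 1.8-fold higher number from compound 1 to compound 3 (0.26 log units; within the scatter) and an estimate of 200 nM, in the range 70 nM to 600 nM.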

Compound 3, half-maximal inhibitory concentration: 70 nM
Compound 3: the middle estimate sits 2.9-fold (0.46 log units) above what was measured; the range from low to high includes it.
By their numbers in this assay, from the lowest: compounds 3, 1 and 2 (each within the scatter of the next, the first and the last beyond it).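

Compound 3 shows that, at this place on the five-membered aromatic ring with 2 nitrogen and 1 oxygen, the whole 4-methylphenyl ring can give way to pyridin-3-yl with no movement beyond the scatter in this assay (a 1.6-fold lower number from compound 1 to compound 3 (0.20 log units; within the scatter)). The earlier pair changed only a small group on a ring that stayed in place, whereas this step replaces the ring itself, with one ring carbon exchanged for nitrogen and the methyl group gone, so the read-out at this position tolerates a larger kind of change than compound 2 could reveal. Nothing available here accounts for this result in terms of how the two rings differ, so the step stands as an observation only.

The compounds shown leave open how far this tolerance extends, for instance to pyridin-4-yl, to a saturated ring such as piperidine, or to a phenyl ring carrying an amine or a carboxylic acid. They also leave open whether a longer chain in place of the ring would keep the number in the same range.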